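Swapping the tert-butyl group on a weak EZH2 series

The compounds below may be only part of what the source reports. "The series", "measured", "known", "first", "only" and "open" are said of these compounds alone.

Measured compounds:
- compound 1 `CC(C)(C)c1ccc(NC(=O)c2ncn(CC(=O)NCCn3ccc4c(N)ncnc43)n2)cc1` gives "not active" (no number reported) in an assay on isolated protein for inhibition of histone-lysine N-methyltransferase EZH2 (Homo sapiens), read by 33P incorporation; a lower number here means a stronger inhibitor, a higher number a weaker inhibitor
- compound 2 `CC(C)(C)c1ccc(NC(=O)c2ncn(CC(=O)NCc3ccc4c(N)nccc4c3)n2)cc1` gives "not active" (no number reported) in this assay
- compound 3 `CC(C)(C)c1ccc(NC(=O)c2ncn(CC(=O)NCc3ccc4[nH]ncc4c3)n2)cc1` gives > 250000 nM in this assay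

The three measured compounds share the same core and differ only in the group carried at the far end of the chain. None of them gives a real number. Compound 1 is simply reported as inactive, with no concentration attached, and compound 2 is reported the same way. For compound 3 the entry is a limit of the measurement rather than a number, which is the point at which the limit of > 250000 nM in this assay, at which 1 of the 3 values shown sits, sits. Compound 1 therefore stands among entries that all sit at or beyond the reach of this assay.

Compound 4 `Cc1ccc(NC(=O)c2ncn(CC(=O)NCCn3ccc4c(N)ncnc43)n2)cc1C` keeps everything of compound 1 except one change: 3,4-dimethylphenyl in place of 4-(tert-butyl)phenyl on an amide-type nitrogen. Within the data shown here, no measured pair shows what such a change does here, so the direction and size of the step cannot be read from the data. With compound 1 reported as "not active" (no number reported), compound 4 is expected to remain inactive as well. The estimate for compound 4 in this assay is 300000 nM, within a range of 50000 nM to 1500000 nM.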

Compound 4, half-maximal inhibitory concentration: "not active" (no number reported)
Compound 4: no number reported; no gap can be computed for the estimate.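

In this assay compound 1 gives "not active" (no number reported) and compound 4 gives "not active" (no number reported), so no step can be read between them. The compounds shown leave open whether 3,4-dimethylphenyl and 4-(tert-butyl)phenyl differ at all, and the only figure among them is a limit: the limit of > 250000 nM in this assay, at which 1 of the 4 values shown sits.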